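Swapping a Halogenated Ring for a Hydroxy-Methoxy Ring

The source may hold more compounds than are shown below. What is called first, only, known or untested is meant among the compounds shown, and "the series" means these compounds.

Two nucleoside-type compounds share one core and differ only in the aromatic ring hanging from a saturated chain carbon bound to a nitrogen on an aromatic ring. Compound 1 `OC[C@H]1O[C@@H](n2cnc3c(NCc4ccc(F)c(F)c4F)ncnc32)[C@H](O)[C@@H]1O` carries a 2,3,4-trifluorophenyl there. In a functional assay on HOS cells (Homo sapiens) for antiproliferative activity, with a stated time of 72 h (a lower number here means a stronger inhibitor, a higher number a weaker inhibitor), compound 1 gives only a limit, > 166000 nM. Compound 2 `OC[C@H]1O[C@@H](n2cnc3c(NCc4ccc(F)c(Cl)c4)ncnc32)[C@H](O)[C@@H]1O` carries a 3-chloro-4-fluorophenyl instead. In this assay compound 2 likewise gives only a limit, > 166000 nM. Both values sit at the limit of > 166000 nM in this assay, at which 2 of the 2 values shown sit, so the step that the two limits leave unreadable from compound 1 to compound 2 cannot be sized. On the numbers shown, compound 2 therefore stands at the limit alongside compound 1, with no number to rank either.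

Compound 3 `COc1cccc(CNc2ncnc3c2ncn3[C@@H]2O[C@H](CO)[C@@H](O)[C@H]2O)c1O` has not yet been measured. It differs from compound 2 as follows: 2-hydroxy-3-methoxyphenyl in place of 3-chloro-4-fluorophenyl on a saturated chain carbon bound to a nitrogen on an aromatic ring. For the measured compounds named here, the only measured step, the one from compound 1 to compound 2, carries no readable size, so the data give no anchor for direction or magnitude. I expect compound 3 to stay near the limit, with an estimated step that the limit leaves unreadable from compound 2 to compound 3. My estimate for compound 3 is 200000 nM, with a range from 50000 nM to 1000000 nM.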

Compound 3, half-maximal inhibitory concentration: > 166000 nM
Compound 3: no number, only a limit (the forecaster's own chance of this, stated with the estimate: 80%); the middle value is on the limit's open side.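

In this assay compound 3 also gives only a limit, so its steps from compound 1 and from compound 2 cannot be read, and the three compounds share one limit: the limit of > 166000 nM in this assay, at which 3 of the 3 values shown sit.

The compounds shown leave open how the three rings rank and whether any ring on this shared core gives a readable number.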